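The compounds below may be only part of what the source reports. "The series", "measured", "known", "first", "only" and "open" are said of these compounds alone.

Compound 1 `Nc1ccc2cccc(OC3CCCCC3)c2n1` gives 361 nM in an assay on cells with melanin-concentrating hormone receptor 1 (Homo sapiens) as the target, read by radioligand binding; on this read-out higher numbers stand for weaker inhibition and lower numbers for stronger inhibition. Compound 2 `CCC#CCOc1cccc2ccc(N)nc12` gives only a limit, > 2000 nM. Compound 3 `CC(COC(C)(C)C)Oc1cccc2ccc(N)nc12` gives 306 nM.

Compound 3 holds the lowest of the two numbers, and compound 1 sits close to it, within the scatter. Compound 4 `CCOCC(C)Oc1cccc2ccc(N)nc12` differs from compound 3 by ethyl in place of tert-butyl on an oxygen on a saturated carbon. Among the measured compounds shown here, the only measured step, an at least 5.5-fold higher number from compound 1 to compound 2 (0.74 log units; beyond the scatter), concerns the group on the oxygen on the aromatic ring, not the outer ether, so no measured step bears directly on this change. With no guide, compound 4 is expected to stay near compound 3, and the step of a 1.3-fold higher number from compound 3 to compound 4 (0.12 log units; within the scatter) is expected to fall within the scatter. Compound 4 is estimated at 400 nM, with a range from 150 nM to 1100 nM.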

Compound 4, half-maximal inhibitory concentration: 1070 nM
Compound 4: middle estimate off by 2.7-fold (0.43 log units), on the low side; the measured number falls inside the stated range.
By their numbers in this assay, from the lowest: compounds 3 and 1 (each within the scatter of the next); then compound 4. At a limit, above all of these: compound 2.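

Ethyl in place of tert-butyl on an oxygen on a saturated carbon is not a silent change: in this assay it gives a modest step, a 3.5-fold higher number from compound 3 to compound 4 (0.54 log units; beyond the scatter). This shows that the group at this far end of the chain counts, even though the rest of the chain stays the same, and the same chain with ethyl also falls short of the cyclohexyl group, with a 3.0-fold higher number from compound 1 to compound 4 (0.47 log units; beyond the scatter). Compound 2 has only a limit: the limit of > 2000 nM in this assay, at which 1 of the 4 values shown sits. Set against that limit, the comparison gives an at least 1.8-fold lower number from compound 2 to compound 4 (0.27 log units; that floor lies within the scatter).

The compounds shown leave open whether isopropyl or cyclohexyl in this place would match tert-butyl. They also leave open how an amine or a carboxylic acid there would fare.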